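This account rests on a few compounds, and the source may have more. Where it says the series, first, only, none or still open, it means among the compounds named here.

Compound 1, with structure `CCCS(=O)(=O)Nc1cccc2c1CCCC2c1c[nH]cn1`, was tested in an assay on isolated protein for binding affinity to Alpha-1D adrenergic receptor (Rattus norvegicus), read by radioligand binding; on this read-out lower numbers stand for stronger inhibition and higher numbers for weaker inhibition. In this assay compound 1 gives only a limit, < 10000 nM, not a measured number. Compound 2, with structure `CCS(=O)(=O)Nc1cccc2c1CCCC2CNC`, belongs to the same series. In this assay compound 2 likewise gives only a limit, < 10000 nM. Both results therefore sit at the limit of < 10000 nM in this assay, at which 2 of the 2 values shown sit, so where compound 1 truly stands is known only as a bound.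

Compound 3, with structure `COC(=O)Nc1cccc2c1CCCC2c1c[nH]cn1`, has not yet been measured. It differs from compound 1 in one place: methoxycarbonyl in place of propylsulfonyl on a nitrogen on an aromatic ring. Both leaving and entering groups carry the same number of hydrogen-bond acceptors and no donors.

With no measured step of this kind in the series, compound 3 is expected to land close to compound 1, a change of about a step that the limit leaves unreadable from compound 1 to compound 3, not beyond the usual scatter. The estimate for compound 3 in this assay is 4000 nM, within 500 nM to 12000 nM.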

Compound 3, inhibition constant: 3020 nM
For compound 3 the middle estimate is 1.3-fold (0.12 log units) above the measured one, and the stated range covers the measured number.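

No step from compound 1 to compound 3 can be read in this assay, because the result for compound 1 is only a limit: the limit of < 10000 nM in this assay, at which 2 of the 3 values shown sit.

The compounds shown leave open whether methoxycarbonyl in place of propylsulfonyl strengthens binding, weakens it or leaves it unchanged.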